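Halogen swap on a dienone scaffold: toxicity toward Vero cells

The compounds below may be only part of what the source reports. "The series", "measured", "known", "first", "only" and "open" are said of these compounds alone.

The measured compounds:
compound 1, `COc1ccc(/C=C(\C)C(=O)/C=C/c2ccccc2Cl)cc1`, 74300 nM
compound 2, `COc1ccc(/C=C(\C)C(=O)/C=C/c2ccccc2Br)cc1`, 71000 nM
compound 3, `CC/C(=C\c1ccc(Cl)cc1)C(=O)/C=C/c1ccc(Br)cc1`, 29400 nM

In an ADME assay on Vero cells (Chlorocebus sabaeus) for cytotoxicity, read by MTT assay, with a stated time of 72 h (on this read-out lower numbers stand for higher toxicity in this test and higher numbers for lower toxicity in this test), compound 1 gives 74300 nM. In this assay compound 2 gives 71000 nM. The change from one to the other is chloro in place of bromo on an aromatic carbon, and the step it made is a 1.0-fold higher number from compound 2 to compound 1 (0.02 log units; within the scatter). Compound 3 stands lowest of the three numbers in this assay with 29400 nM; its nearest neighbour is compound 2, and the gap to both compound 2 and compound 1 is beyond the scatter. How the core of compound 3 differs from the core of compound 2 is not broken down here.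

Compound 4, `CC/C(=C\c1ccc(Cl)cc1)C(=O)/C=C/c1ccc(Cl)cc1`, has not yet been measured in this assay. It differs from compound 3 by chloro in place of bromo on an aromatic carbon. This is the same kind of change as that from compound 2 to compound 1, but not the same: in compound 4 the halogen sits para to a large group, whereas in compound 1 it sits ortho to a large group. Since the earlier step, a 1.0-fold higher number from compound 2 to compound 1 (0.02 log units; within the scatter), lay within the scatter, the step from compound 3 to compound 4 is expected to be small as well, estimated at a 1.0-fold higher number from compound 3 to compound 4 (0.01 log units; within the scatter). Compound 4 is therefore expected to give about 30000 nM in this assay, with a plausible range from 15000 nM to 60000 nM.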

Compound 4, half-maximal cytotoxic concentration: 28300 nM
The estimate for compound 4 lay 1.1-fold (0.03 log units) above the measured number; measured number inside the range.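

In this assay the exchange of 4-bromophenyl for 4-chlorophenyl gives a 1.0-fold lower number from compound 3 to compound 4 (0.02 log units; within the scatter) and thus no readable shift in cytotoxicity. Set beside the earlier exchange of bromo for chloro on the other core, the new step does not differ from it: the same change on two cores in this assay, a 1.0-fold higher number (0.02 log units; within the scatter) from compound 2 to compound 1 and a 1.0-fold lower number (0.02 log units; within the scatter) from compound 3 to compound 4, 1.1-fold (0.04 log units) apart, within the scatter of two such steps. On these two cores, one of them with the halogen para to a large group, chloro could therefore take the place of bromo without moving the number beyond the scatter, but two pairs do not show that this would carry over to any further core, and they give no reason for the agreement.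

The compounds shown carry only chloro and bromo as the exchanged halogens, so it remains open whether fluoro, iodo or trifluoromethyl in the same place would also leave the number within the scatter. From the compounds shown here alone, it is equally open how the number would respond to an amine or a carboxylic acid on the aromatic ring, or to a longer chain on the shared core.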